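The source may report more compounds than this note shows. Statements on the series, on what has been measured and on what is new or still open speak of the compounds shown alone.

Series as measured in an ADME assay on RD cells (Homo sapiens) for cytotoxicity, read by MTT assay, with a stated time of 3 days; on this read-out higher numbers stand for lower toxicity in this test and lower numbers for higher toxicity in this test:

compound 1, `CC[C@@H](CCn1cncn1)c1ccc(F)cc1`, gives 91.6 ug/mL
compound 2, `CC[C@@H](CCn1cncn1)c1ccc(C)cc1`, gives 79.4 ug/mL
compound 3, `CCCC[C@H](CCn1cncn1)c1ccc(F)cc1`, gives 35.2 ug/mL

Compound 1 and compound 2 differ in one place, (methyl in place of fluoro on an aromatic carbon), and the step there is a 1.2-fold lower number from compound 1 to compound 2 (0.06 log units; within the scatter). Compound 3 gives the lowest number of the three; compound 2 and compound 1 lie above it, both beyond the scatter. The difference between the core of compound 1 and the core of compound 3 is not broken down here.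

Compound 4, `CCCC[C@H](CCn1cncn1)c1ccc(C)cc1`, is not yet measured in this assay. It differs from compound 3 by methyl in place of fluoro on an aromatic carbon, the same change as from compound 1 to compound 2. The expected step to compound 4 is a 1.2-fold lower number from compound 3 to compound 4 (0.07 log units; within the scatter), resting on the earlier 1.2-fold lower number from compound 1 to compound 2 (0.06 log units; within the scatter). Compound 4 is therefore estimated at 30 ug/mL, expected between 15 ug/mL and 60 ug/mL.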

Compound 4, half-maximal cytotoxic concentration: 26.5 ug/mL
Compound 4: middle estimate off by 1.1-fold (0.05 log units), on the high side; measured number inside the range.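

In this assay, methyl in place of fluoro on the second core gives a 1.3-fold lower number from compound 3 to compound 4 (0.12 log units; within the scatter), and the change carries across the two cores with no difference that can be told apart: the same change on two cores in this assay, a 1.2-fold lower number (0.06 log units; within the scatter) from compound 1 to compound 2 and a 1.3-fold lower number (0.12 log units; within the scatter) from compound 3 to compound 4, 1.2-fold (0.06 log units) apart, within the scatter of two such steps. Both steps lie within the scatter, so on these two cores the change cannot be told from no change at all. This does not show that a step of measurable size transfers, nor that the same would hold on any other core in the series.

The compounds shown leave open whether chloro, methoxy or trifluoromethyl at that aromatic carbon would move the number beyond the scatter. Also open, going by these compounds, is what an amine or a carboxylic acid on the chain would do.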